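Expected Cytotoxicity of a New tert-Butyl Analogue

The compounds below may be only part of what the source reports. "The series", "measured", "known", "first", "only" and "open" are said of these compounds alone.

Measured compounds:
compound 1, `COC(=O)c1ccc(NCc2cncn2Cc2ccccc2Br)cc1-c1ccccc1`, 10000 nM
compound 2, `COC(=O)c1ccc(NCc2cncn2Cc2ccccc2F)cc1-c1ccccc1`, "not determined" (no result reported)
compound 3, `COC(=O)c1ccc(NCc2cncn2Cc2ccc(OC)cc2)cc1-c1ccccc1`, "not determined" (no result reported)

The three compounds share one core and differ only in the group carried on a saturated chain carbon bound to an aromatic nitrogen. In a toxicity assay on NIH3T3 cells (Mus musculus) for cytotoxicity, read by resazurin assay (on this read-out lower numbers stand for an effect already at smaller amounts and higher numbers for an effect only at larger amounts of compound), compound 1 gives 10000 nM. For compound 2 the outcome in this assay is "not determined" (no result reported), so no number is available for it. Compound 3 likewise has no single number, its entry in this assay reading "not determined" (no result reported); it therefore cannot be placed against compound 1 on the numbers shown, and one further entry in the set is in the same situation.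

The next compound, compound 4 with structure `COC(=O)c1ccc(NCc2cncn2Cc2cccc(C(C)(C)C)c2)cc1-c1ccccc1`, is reached from compound 3 by the change (3-(tert-butyl)phenyl in place of 4-methoxyphenyl on a saturated chain carbon bound to an aromatic nitrogen).

For the measured compounds named here, since no step between measured compounds exists here, the only anchor is the single value of compound 1. The change from compound 3 to compound 4 keeps the core untouched, and nothing in the data suggests that the exchanged group moves the read-out beyond the usual scatter. Compound 4 is therefore expected to give 10000 nM in this assay, with the estimate spanning 3000 nM to 30000 nM.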

Compound 4, half-maximal effective concentration: > 1000 nM
Compound 4: a limit, no number; the forecaster's own chance of this, stated with the estimate: 40%; the middle value is on the limit's open side.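

In this assay compound 4 gives > 1000 nM, which is a limit and not a number. For the compounds shown here, no step can therefore be read from compound 1 to compound 4. The compounds shown leave open how the 3-(tert-butyl)phenyl group of compound 4 compares with the 2-bromophenyl group of compound 1 or the 4-methoxyphenyl group of compound 3 in this assay.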